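This account rests on a few compounds, and the source may have more. Where it says the series, first, only, none or still open, it means among the compounds named here.

Measured compounds in a functional assay on HEK293 cells for agonist activity at transient receptor potential cation channel subfamily V member 1 (Homo sapiens); on this read-out higher numbers stand for larger maximal responses and lower numbers for smaller maximal responses:
- compound 1 `Cc1ccc(C(=O)N[C@@H]2C[C@H](C)CC[C@H]2C(C)C)cc1` with 5.4%
- compound 2 `CC(C)[C@@H]1CC[C@@H](C)C[C@H]1NC(=O)CCCCCCCc1ccccc1` with 5.5%

Compound 1 carries a methyl-substituted benzamide on the shared core, and in this assay compound 1 gives 5.4%. Compound 2 carries instead a long chain ending in a phenyl ring, and in this assay compound 2 gives 5.5%. For the measured compounds named here, the two values lie within the scatter of each other, so the numbers alone do not set one compound apart from the other; both sit near the bottom of the scale of this assay, and no step between them is drawn here.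

The unmeasured compound 3 `CC(C)[C@@H]1CC[C@@H](C)C[C@H]1NC(=O)c1ccc(Cl)cc1` keeps the core of compound 1 and changes only the aromatic substituent: chloro in place of methyl on an aromatic carbon. Since both measured compounds give small maximal responses in this assay and nothing in the shown numbers points to a rise, the step from compound 1 to compound 3 is expected to stay within the scatter, with a number 0.6 percentage points higher from compound 1 to compound 3 (within the scatter). Compound 3 is therefore estimated to reach 6% in this assay, within a range from 1% to 15%.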

Compound 3, largest response reached (reported as efficacy), in percent of the reference or control that the assay uses: 53.8%
Estimate against measurement, compound 3: 47.8 percentage points below; the whole stated range lies below it.
By their numbers in this assay, from the lowest: compounds 1 and 2 (each within the scatter of the next); then compound 3.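

In this assay, the exchange of methyl for chloro on an aromatic carbon, para to a large group, gives a number 48.4 percentage points higher from compound 1 to compound 3 (beyond the scatter) and shows that this single place can carry a large change in maximal response, which the earlier pair, lying within the scatter of each other, gave no sign of. By the count of atoms the change is small: one heavy atom leaves and one enters, and neither group brings a ring, a hydrogen-bond donor, a hydrogen-bond acceptor or a net charge, so a swap that leaves all these counts unchanged is still enough to produce a step of this size on the shared core. No measurement shown here accounts for the size of this step.

Whether the high response is particular to chloro or is shared by other groups at this place, such as fluoro, bromo, trifluoromethyl or methoxy, remains open, since the compounds shown offer only methyl and chloro there. It also remains open whether chloro on another carbon of the same ring would give a similar response, and whether the step would recur with a core other than the one shown.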